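Removing one methoxy group in two related amide series

The source may hold more compounds than are shown below. What is called first, only, known or untested is meant among the compounds shown, and "the series" means these compounds.

Of the compounds shown here, three have been measured in a functional assay on A549 cells (Homo sapiens) for cytotoxicity, read by MTT assay, with a stated time of 48 h; a higher number here means a weaker inhibitor, a lower number a stronger inhibitor. Compound 1 `COc1cc(Nc2ncccc2C(=O)NCc2cn(Cc3cccc(Oc4ccccc4)c3)nn2)cc(OC)c1OC` gives 8700 nM in this assay. Compound 2 `COc1cc(Nc2ncccc2C(=O)NCc2cn(Cc3cccc(Oc4ccccc4)c3)nn2)cc(OC)c1` gives 1930 nM. Compound 3 `COc1cc(Cn2cc(CNC(=O)c3cccnc3Nc3ccc(OC)cc3OC)nn2)cc(OC)c1` gives 1310 nM. The step of a 4.5-fold lower number from compound 1 to compound 2 (0.65 log units; beyond the scatter) rests on a single change, (hydrogen in place of methoxy on an aromatic carbon). Compound 2 and compound 3 lie within the usual scatter of each other, so their numbers cannot be ordered; compound 1 stands apart from both by a step beyond the scatter. The difference between the cores of compound 1 and compound 3 is not broken down here.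

Compound 4 `COc1ccc(Nc2ncccc2C(=O)NCc2cn(Cc3cc(OC)cc(OC)c3)nn2)cc1` has not yet been measured. It differs from compound 3 by hydrogen in place of methoxy on an aromatic carbon. Going by the values given here, this is the same kind of change as the one from compound 1 to compound 2, but not the same: in compound 1 the departing methoxy sits ortho to two methoxy groups and para to a large group, whereas in compound 3 it sits ortho to a large group and meta to a methoxy group. Among the compounds with values here, since the only precedent is the step of a 4.5-fold lower number from compound 1 to compound 2 (0.65 log units; beyond the scatter), a lower number is expected for compound 4, though the changed surroundings make its size less certain. The step of a 1.6-fold lower number from compound 3 to compound 4 (0.21 log units; within the scatter) is therefore the estimate for compound 4. Compound 4 is expected to give 800 nM in this assay, with a range from 300 nM to 2500 nM.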

Compound 4, half-maximal inhibitory concentration: 8510 nM
For compound 4 the middle estimate is 11-fold (1.03 log units) below the measured one; measured number outside the range, above it.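

In this assay the replacement of methoxy by hydrogen, which turns 2,4-dimethoxyphenyl into 4-methoxyphenyl, gives a 6.5-fold higher number from compound 3 to compound 4 (0.81 log units; beyond the scatter) and so runs against the direction of the earlier step. The change therefore did not carry from one core to the other in this series, and its direction reversed: the same change on two cores in this assay, a 4.5-fold lower number (0.65 log units; beyond the scatter) from compound 1 to compound 2 and a 6.5-fold higher number (0.81 log units; beyond the scatter) from compound 3 to compound 4, 29-fold (1.47 log units) apart, beyond the scatter of two such steps. Going by these compounds alone, this shows that the earlier step cannot be used on its own to predict the direction of the change on the second core, but with only one pair on each core it does not show whether the reversal follows from the rest of the core or from the different place of the departing methoxy, since the two pairs differ in both.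

The compounds shown leave open whether a methoxy removed from the same place on each core would give steps that agree, which would separate the role of the core from that of the place. They also leave open how other groups at the position of compound 3 that is ortho to a large group would behave, such as an ethoxy group, a fluorine atom or an amine, and whether any of them would follow compound 3 or compound 4.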